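This account rests on a few compounds, and the source may have more. Where it says the series, first, only, none or still open, it means among the compounds named here.

Compound 1 `COc1cccc(-c2c(S(=O)(=O)c3ccc(C)c(F)c3)cnc3c(F)cccc23)c1` stands highest of the three numbers in an ADME assay on microsomes from liver (Homo sapiens) for metabolic stability, tested at 2.5 uM (on this read-out higher numbers stand for fast clearance and lower numbers for slow clearance), giving 4.02 mL/min, though the nearest value is within the usual scatter. Compound 2 `COc1ccc(-c2c(S(=O)(=O)c3ccc(C)c(F)c3)cnc3c(F)cccc23)cc1` gives 3.27 mL/min, and the step of a 1.2-fold lower number from compound 1 to compound 2 (0.09 log units; within the scatter). Compound 3 `O=S(=O)(c1cc(F)cc(F)c1)c1cnc2cc(F)ccc2c1-c1cccc(Cl)c1` gives 0.22 mL/min; it differs from compound 1 in more than one place, so the two values can only be set side by side. Among the compounds with values here, compound 4 `COc1cccc(-c2c(S(=O)(=O)c3cc(Cl)cc(Cl)c3)cnc3c(F)cccc23)c1` is not yet measured in this assay. 3,5-dichlorophenyl in place of 3-fluoro-4-methylphenyl on a sulfonyl sulfur No measured step changes the group on the sulfonyl sulfur alone, so no step bears directly on this change, and the wide gap between compound 1 and compound 3 cannot be assigned to it. The step of a 2.0-fold lower number from compound 1 to compound 4 (0.30 log units; within the scatter) is expected to be a modest lowering of the number, with wide uncertainty. For compound 4 the estimate is 2 mL/min, in the range 0.5 mL/min to 6 mL/min.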

Compound 4, intrinsic clearance in a liver preparation (reported as CLH), per the amount of preparation that the assay uses: 2.31 mL/min
The estimate for compound 4 lay 1.2-fold (0.06 log units) below the measured number; the measured number falls inside the stated range.
By their numbers in this assay, from the lowest: compound 3; then compounds 4, 2 and 1 (each within the scatter of the next).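

Within the data shown here, on the sulfonyl sulfur, 3,5-dichlorophenyl in place of 3-fluoro-4-methylphenyl gives in this assay a 1.7-fold lower number from compound 1 to compound 4 (0.24 log units; within the scatter), the first direct reading at this position. The two aryl groups are therefore not told apart in this read-out, with the 3-methoxyphenyl and the core of compound 1 held fixed. No supporting measurement bears on this result.

Going by these compounds, whether a sulfonyl sulfur carrying an amine-bearing phenyl, a carboxylic acid-bearing phenyl or a short alkyl chain would give a step beyond the scatter remains open. On these data alone, whether the same change reads alike with the 4-methoxyphenyl of compound 2 also remains open.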